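A few compounds are considered here, and "the series" means these few. Any claim that something is new, unique, unknown or untested is made for them only; others in the source may bear on it.

Measured compounds and their results in a functional assay on the whole organism (artery, strain albino) with Rattus norvegicus as the target, with a stated time of 240 min, at a dose of 10 mg/kg by the oral route; a higher number here means more inhibition at the dose given (going by the name of the read-out), a lower number less inhibition:

Compound 1 `CC1=C(C(=O)Nc2ccc(Br)cc2)C(c2ccc(Cl)cc2Cl)N=C(SCc2ccccc2Cl)N1`: 28.7%
Compound 2 `CC1=C(C(=O)Nc2ccc(Br)cc2)C(c2ccc(Cl)cc2Cl)N=C(SCc2cccc(Cl)c2)N1`: 15.9%
Compound 3 `CC1=C(C(=O)Nc2ccc([N+](=O)[O-])cc2)C(c2ccc(Br)cc2)N=C(SCc2ccccc2Cl)N1`: 15.4%

Compound 1 and compound 2 share one core and differ in a single place: 3-chlorophenyl in place of 2-chlorophenyl on a saturated chain carbon bound to a sulfur. That change gives a number 12.8 percentage points lower from compound 1 to compound 2 (beyond the scatter). Compound 3 stands on a different core; the difference between the two cores is not broken down here. Of the three results, compound 3 and compound 2 lie within the usual scatter of each other, while compound 1 is clearly higher than compound 3.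

Compound 4 `CC1=C(C(=O)Nc2ccc([N+](=O)[O-])cc2)C(c2ccc(Br)cc2)N=C(SCc2cccc(Cl)c2)N1` has not yet been measured in this assay. It stands to compound 3 exactly as compound 2 stands to compound 1: 3-chlorophenyl in place of 2-chlorophenyl on a saturated chain carbon bound to a sulfur. This is the same change, at the same place, that was seen once before in the shared series.

If the earlier step carries over, compound 4 is expected to sit lower than compound 3 by about a number 10.4 percentage points lower from compound 3 to compound 4 (beyond the scatter), an expectation that rests on the drop from compound 1 to compound 2 of a number 12.8 percentage points lower from compound 1 to compound 2 (beyond the scatter) and on the result of compound 3 of 15.4%. Since a percentage of inhibition cannot fall below nothing, the room for a drop is limited. Compound 4 is therefore estimated to give 5% in this assay, most likely between 0% and 18%.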

Compound 4, a percentage reported as inhibition, in the whole organism at one dose (the size of the read-out at that dose, not a potency): 11.8%
Compound 4: middle estimate off by 6.8 percentage points, on the low side; the measured number falls inside the stated range.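

In this assay, 3-chlorophenyl in place of 2-chlorophenyl on a saturated chain carbon bound to a sulfur gives a number 3.6 percentage points lower from compound 3 to compound 4 (within the scatter), so on this core the step cannot be told apart from the scatter of repeated measurements. Set beside the earlier step on the other core, the two steps cannot be told apart either: the same change on two cores in this assay, a number 12.8 percentage points lower (beyond the scatter) from compound 1 to compound 2 and a number 3.6 percentage points lower (within the scatter) from compound 3 to compound 4, 9.2 percentage points apart, within the scatter of two such steps The change therefore cannot be said to behave differently on the two cores, but this does not show that it carries over with a fixed size, as each core offers only a single pair and only the step on the core of compound 1 stands clear of the scatter.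

Going by these compounds, it remains open how the result would shift with an unsubstituted benzyl, a methoxybenzyl or a longer alkyl chain on the sulfur. Also open is what each of the differences between the two cores contributes, as these are not separated by any pair shown here.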